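The source may hold more compounds than are shown below. What is called first, only, known or untested is meant among the compounds shown, and "the series" means these compounds.

Compound 1 `O=c1c(-c2nn[nH]n2)c[nH]c2ccccc12`: in a functional assay on the whole organism (strain Sprague-Dawley) for inhibition, with Rattus norvegicus as the target (a lower number here means that less compound is needed, a higher number that more compound is needed for the effect), compound 1 gives 1.25 mg/kg.
Compound 2 `O=c1c(-c2nn[nH]n2)c[nH]c2ccc(Cl)cc12`: in this assay compound 2 gives > 10 mg/kg, which is a limit of the assay and not a number.
Compound 3 `O=c1c(-c2nn[nH]n2)c[nH]c2c(Cl)cc(Cl)cc12`: in this assay compound 3 gives > 0.156 mg/kg, also a limit of the assay and not a number.

Compound 2 therefore stands at the limit of > 10 mg/kg in this assay, at which 1 of the 3 values shown sits, and its exact position on the scale is not known. The next compound to consider is compound 4 `CCc1ccc2[nH]cc(-c3nn[nH]n3)c(=O)c2c1`, which has not yet been measured. It differs from compound 2 in one place: ethyl in place of chloro on an aromatic carbon.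

Two measured steps surround compound 2. The step of an at least 8.0-fold higher number from compound 1 to compound 2 (0.90 log units; beyond the scatter) shows that putting a chloro on this aromatic carbon cost a clearly readable amount in this assay. The step that the two limits leave unreadable from compound 2 to compound 3, by contrast, cannot be sized, since both ends are limits. Only the first step speaks to compound 4: the chloro that hurt in an at least 8.0-fold higher number from compound 1 to compound 2 (0.90 log units; beyond the scatter) is taken away, but an ethyl is put in its place, and nothing measured here shows what an ethyl on this aromatic carbon does. The expectation is thus a modestly lower number than the limit of compound 2, with wide uncertainty in both directions.

Compound 4 is expected to give about 5 mg/kg, with a range from 1.5 mg/kg to 20 mg/kg. This estimate corresponds to an expected step of an at least 2.0-fold lower number from compound 2 to compound 4 (0.30 log units; that floor lies within the scatter).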

Compound 4, minimum effective dose: < 5 mg/kg
Compound 4: only a limit was reported (the forecaster's own chance of this, stated with the estimate: 40%); the middle value sits exactly at the limit.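

In this assay compound 4 gives < 5 mg/kg, which is a limit of the assay and not a number. Even so, replacing chloro with ethyl on this aromatic carbon gives a readable step, an at least 2.0-fold lower number from compound 2 to compound 4 (0.30 log units; that floor lies within the scatter), and this adds something the earlier compounds could not show: they showed only that chloro in place of hydrogen here raised the number, whereas this step suggests that the outcome depends on which group sits at this carbon, although the guaranteed size of the step does not exceed the usual scatter. Nothing shown here gives a measured property of chloro or ethyl that could explain this difference.

As far as these compounds go, the step between compound 1 and compound 4 cannot be read, so it remains open whether ethyl at this carbon matches hydrogen or costs something, and exact values for compound 2 and compound 4 would be needed to size the change from chloro to ethyl. From the compounds shown here alone, it is also open how a longer chain such as propyl, or an amine, would behave on this same aromatic carbon.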